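A few compounds are considered here, and "the series" means these few. Any claim that something is new, unique, unknown or untested is made for them only; others in the source may bear on it.

Compound 1 `Cc1noc(-c2nc(C)c3c(c2N)C(=O)N(Cc2ccc(-n4cccn4)cc2)C3=O)n1`: in a physicochemical assay for solubility, using the shake flask method, in simulated intestinal fluid, measured as kinetic solubility, with a stated time of 2 h, at 25 degrees C, at pH 6.5 (a lower number here means a less soluble compound, a higher number a more soluble compound), compound 1 gives < 5000 nM, a limit of the assay.
Compound 2 `COc1ccc(CN2C(=O)c3c(C)nc(-c4nc(C)no4)c(N)c3C2=O)cc1`: in this assay compound 2 gives < 5000 nM, also a limit.

Within the data shown here, compound 1 therefore stands only at a limit of this assay, and the one further value shown is a limit as well (the limit of < 5000 nM in this assay, at which 2 of the 2 values shown sit). Among the measured compounds shown here, the only measured step, a step that the two limits leave unreadable from compound 1 to compound 2, is unreadable between two limits.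

Compound 3 `Cc1noc(-c2nc(C)c3c(c2N)C(=O)N(Cc2ccc(N(C)C)cc2)C3=O)n1` differs from compound 1 by dimethylamino in place of 1H-pyrazol-1-yl on an aromatic carbon. No readable step bears on this change, so compound 3 is expected, like compound 1, to sit at the limit, with an estimate of 3000 nM (range 500 nM to 9000 nM). This estimate means an expected step that the limit leaves unreadable from compound 1 to compound 3.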

Compound 3, solubility: 7400 nM
Compound 3: middle estimate off by 2.5-fold (0.39 log units), on the low side; the range from low to high includes it.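

With dimethylamino at this aromatic carbon, compound 3 gives a measured number in this assay, whereas the other two compounds remain at a limit: the limit of < 5000 nM in this assay, at which 2 of the 3 values shown sit. Dimethylamino in place of 1H-pyrazol-1-yl gives an at least 1.4-fold higher number from compound 1 to compound 3 (0.17 log units; that floor lies within the scatter), and dimethylamino in place of methoxy gives an at least 1.4-fold higher number from compound 2 to compound 3 (0.17 log units; that floor lies within the scatter). As far as these compounds go, both steps are floors only, so their true size remains unknown.

The compounds shown leave open whether a larger amine such as morpholine, or a carboxylic acid, at this place would give a readable number. They also leave open how far compound 1 and compound 2 truly lie from compound 3.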